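The compounds below may be only part of what the source reports. "The series", "measured", "known", "first", "only" and "open" are said of these compounds alone.

Going by the values given here, in a functional assay on HeLa cells (Homo sapiens) for inhibition, read by WST assay, with stated times of 72 h and 2 h (on this read-out higher numbers stand for weaker inhibition and lower numbers for stronger inhibition), compound 1 `C#CCOC(c1cccs1)c1cc2ccccc2nc1Cl` gives 34700 nM, the only number so far. In this assay compound 2 `Clc1nc2ccccc2cc1C(OCc1ccccc1)c1cccs1` is reported as "not active" (no number reported), so it has no single number and can be placed only by that report. Compound 3 `Clc1ccc(COC(c2cccs2)c2cc3ccccc3nc2Cl)cc1` is the next structure to read. The change is chloro in place of hydrogen on an aromatic carbon, para to a large group, turning benzyl into 4-chlorobenzyl. Among the compounds with values here, no measured pair shows what this change does, and the starting point has no number. The expectation in this assay is therefore no step beyond the scatter, with the read-out staying weak, in the range of compound 1 at 34700 nM or again without a number. For compound 3 the expected value is 45000 nM, with an estimated range of 18000 nM to 110000 nM.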

Compound 3, half-maximal inhibitory concentration: "not active" (no number reported)
Nothing numeric was reported for compound 3; there is nothing to compare the estimate with.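

In this assay compound 2 gives "not active" (no number reported) and compound 3 gives "not active" (no number reported), so no step can be read for benzyl to 4-chlorobenzyl. The compounds shown leave open whether this change affects inhibition at all. Nothing available bears on this result.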